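Demethylating an Aryl Methoxy Group in a Cytotoxicity Series

A few compounds are considered here, and "the series" means these few. Any claim that something is new, unique, unknown or untested is made for them only; others in the source may bear on it.

Compound 2 `COc1ccc(/C=N/c2c(C)n(C)n(-c3ccccc3)c2=O)cc1OC` stands highest of the two numbers recorded in a functional assay on HT-29 cells (Homo sapiens) for cytotoxicity, read by MTT assay, with a stated time of 72 h (a lower number here means a stronger inhibitor, a higher number a weaker inhibitor), where compound 2 gives 603000000 nM. Within the data shown here, its nearest neighbour is compound 1 `COc1cccc(/C=N/c2c(C)n(C)n(-c3ccccc3)c2=O)c1`, for which this assay gives 155000000 nM; the single measured step, a 3.9-fold higher number from compound 1 to compound 2 (0.59 log units; beyond the scatter), was a modest rise beyond the scatter. Compound 3 `COc1cc(/C=N/c2c(C)n(C)n(-c3ccccc3)c2=O)ccc1O` is not yet measured; it differs from compound 2 by hydrogen in place of methyl on an oxygen on an aromatic ring. Among the measured compounds shown here, no measured step involves a methoxy-to-hydroxy change, so the one available step, which concerned a methoxy entering where hydrogen had been, bears on it only indirectly and only suggests that removing a methyl from that substituent is unlikely to move the number far. Compound 3 is therefore expected to show no step beyond the scatter, a 1.5-fold lower number from compound 2 to compound 3 (0.18 log units; within the scatter). The estimate for compound 3 is 400000000 nM, with a range from 150000000 nM to 1200000000 nM.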

Compound 3, half-maximal inhibitory concentration: 537000000 nM
Compound 3: the middle estimate sits 1.3-fold (0.13 log units) below what was measured; measured number inside the range.
By their numbers in this assay, from the lowest: compound 1; then compounds 3 and 2 (each within the scatter of the next).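

Removing the methyl from this oxygen gives a 1.1-fold lower number from compound 2 to compound 3 (0.05 log units; within the scatter) in this assay, so at this position the methoxy and hydroxy groups are not told apart by the number. Hydroxy in place of hydrogen on the aromatic carbon gives a 3.5-fold higher number from compound 1 to compound 3 (0.54 log units; beyond the scatter), and methoxy in the same place gave a 3.9-fold higher number from compound 1 to compound 2 (0.59 log units; beyond the scatter). The modest rise beyond the scatter therefore appears with either group and does not depend on the methyl being present.

What the compounds shown leave open is how a different group at this position, such as an amine, a carboxylic acid or a longer chain on the oxygen, would read in this assay. They also leave open whether any group here would give a number on the lower side of compound 1. Nothing available offers an explanation for these results.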